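Working notes: from compound 2 to compound 4

The source may hold more compounds than are shown below. What is called first, only, known or untested is meant among the compounds shown, and "the series" means these compounds.

Measured so far in a functional assay on L1210 cells (Mus musculus) for inhibition, with a stated time of 48 h; a higher number here means a weaker inhibitor, a lower number a stronger inhibitor:
- compound 1 `CNCCCNCCCNC` gives > 100000 nM (a limit)
- compound 2 `CCNCCCNCCCN` gives > 100000 nM (a limit)
- compound 3 `CCCNCCCNCCCN` gives > 100000 nM (a limit)

Compound 2 has no numerical reading, only a limit of the assay, and the two other measured compounds are no different. Among the compounds with values here, the series so far shows the limit of > 100000 nM in this assay, at which 3 of the 3 values shown sit, and nothing finer.

The next compound is compound 4 `CCNCCCNCCCCN`, which differs from compound 2 by aminomethyl in place of amino on a saturated chain carbon, three bonds along the chain from an amine nitrogen.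

Within the data shown here, one measured step bears on this change, and only loosely: a step that the two limits leave unreadable from compound 2 to compound 3 (methyl in place of hydrogen on a saturated chain carbon, two bonds along the chain from an amine nitrogen). It gives no size to carry over, so the data support no direction for the new change. With no measured number to start from, no shift beyond the scatter is expected in this assay, and a further limit is the likeliest report. The expected outcome is a number no higher from compound 2 to compound 4 (the limit leaves the size open) as a working estimate. For compound 4 the estimated value is 100000 nM (expected range 40000 nM to 250000 nM).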

Compound 4, half-maximal inhibitory concentration: > 100000 nM
Compound 4 was reported as a limit; the forecaster's own chance of this, stated with the estimate: 85%; the middle value lies on the limit itself.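

Compound 4 is reported only as a limit, and so is compound 2, so no step can be read between them in this assay. The compounds shown leave open how strong an inhibitor any of them is and whether any of these chain changes shifts the read-out, as all rest on one value: the limit of > 100000 nM in this assay, at which 4 of the 4 values shown sit.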